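The source may report more compounds than this note shows. Statements on the series, on what has been measured and on what is new or still open speak of the compounds shown alone.

Working notes on the series.

Three compounds carry a measured number. Compound 1 `COc1cccc(C(=O)C2OC2c2ccc(F)cc2)c1` gives 17 nM in a functional assay on HepG2 cells (Homo sapiens) for antiproliferative activity, read by sulforhodamine B assay, with a stated time of 48 h; on this read-out higher numbers stand for weaker inhibition and lower numbers for stronger inhibition. Compound 2 `COc1cc(C2=CC(c3ccc(Cl)cc3)NC(=S)N2)cc(OC)c1OC` gives 11 nM in the same read-out, and compound 3 `COc1ccc(C2=NN(c3ccccc3)C(c3ccc(F)cc3)C2O)cc1` gives 13 nM. Compound 2 stands close to both of the others: its gap to compound 3 and its gap to compound 1 are each within the usual scatter of repeated measurements, so the three numbers form one tight cluster and no ordering among them can be read.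

Compound 4 `COc1ccc(C2C=C(c3cc(OC)c(OC)c(OC)c3)NC(=S)N2)cc1` has not yet been measured. Against compound 2 the change is methoxy in place of chloro on an aromatic carbon, on an aromatic carbon of a six-membered aromatic ring of carbon only, para to a large group; cut one bond further out it reads 4-chlorophenyl to 4-methoxyphenyl. Among the measured compounds shown here, no pair of measured compounds shows this change on its own, so there is no measured step to lean on. Compound 3 already carries a 4-methoxyphenyl group on a different core and gives 13 nM, within the scatter of compound 2, which is weak support for a small effect.

The step from compound 2 to compound 4 in this assay is therefore expected to be a 1.3-fold higher number from compound 2 to compound 4 (0.10 log units; within the scatter), that is, nothing beyond the scatter in either direction. The number for compound 4 is estimated at 14 nM, with a range from 6 nM to 35 nM.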

Compound 4, half-maximal inhibitory concentration: 90 nM
Compound 4: middle estimate off by 6.4-fold (0.81 log units), on the low side, and the stated range ends below it.
By their numbers in this assay, from the lowest: compounds 2, 3 and 1 (each within the scatter of the next); then compound 4.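

In this assay, among the compounds shown here, this place on the shared core proves sensitive to substitution: methoxy in place of chloro gives an 8.2-fold higher number from compound 2 to compound 4 (0.91 log units; beyond the scatter) and is the first step to lie beyond the scatter. For the compounds shown here, the tight cluster formed by the first three numbers gave no sign of this, and no measured pair had yet tested any change at this position. On this core, then, 4-chlorophenyl and 4-methoxyphenyl cannot be treated as interchangeable in this read-out, although the compounds shown offer nothing that accounts for the step, so only its size and direction can be stated.

As far as these compounds go, it remains open how an unsubstituted phenyl, or fluoro, hydroxy, ethoxy or an amine at this place, would read on the shared core, and therefore whether chloro is specifically favoured or methoxy specifically disfavoured. Also open, from the compounds shown here alone, is whether the same exchange on the core of compound 1 or the core of compound 3 would give a step of similar size, and whether this single pair holds for other substituents on the shared core.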